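The source may report more compounds than this note shows. Statements on the series, on what has been measured and on what is new or still open speak of the compounds shown alone.

Measured so far in an ADME assay on the whole organism for inhibition, with Echinochloa crus-galli var. formosensis as the target, with a stated time of 4 days (on this read-out higher numbers stand for weaker inhibition and lower numbers for stronger inhibition), are these compounds:

compound 1 `CCNc1nc(Cl)nc(N[C@@H](C)c2ccccc2)n1` gives 30900 nM
compound 2 `CCCNc1nc(Cl)nc(N[C@H](C)c2ccccc2)n1` gives 33100 nM
compound 3 `CC[C@H](C)Nc1nc(Cl)nc(N[C@H](C)c2ccccc2)n1` gives 52500 nM

All three lie within the scatter of one another, so compound 3 is not separated from compound 1 or compound 2. Compound 4 `CC[C@@H](C)Nc1nc(Cl)nc(N[C@H](C)c2ccccc2)n1` is the partner of compound 3 at one stereocentre (the two compounds have the same atoms and bonds and differ only in configuration as drawn: 1 of 2 stereo elements differ; a stereocentre at a saturated chain carbon is drawn S in compound 3 and R in compound 4). Going by the values given here, the only measured step at that saturated chain carbon adds a methyl (a 1.6-fold higher number from compound 2 to compound 3 (0.20 log units; within the scatter)), and no measured pair inverts this centre. Given that small step, no change beyond the scatter is expected in this assay, and the expected step is a 1.2-fold lower number from compound 3 to compound 4 (0.07 log units; within the scatter) as an estimate. The estimate for compound 4 is 45000 nM with an expected range from 20000 nM to 100000 nM as its span.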

Compound 4, half-maximal inhibitory concentration: 4570 nM
Compound 4: the middle estimate sits 9.8-fold (0.99 log units) above what was measured; measured number below the stated range.
By their numbers in this assay, from the lowest: compound 4; then compounds 1, 2 and 3 (each within the scatter of the next).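

In this assay, going by these compounds alone, the configuration at the saturated chain carbon proves decisive, a result the earlier compounds could not show: moving from S to R gives an 11-fold lower number from compound 3 to compound 4 (1.06 log units; beyond the scatter). Methyl in place of hydrogen at this carbon gives a 7.2-fold lower number from compound 2 to compound 4 (0.86 log units; beyond the scatter) when drawn R, whereas drawn S it gives only a 1.6-fold higher number from compound 2 to compound 3 (0.20 log units; within the scatter). The gap can be traced to this stereocentre alone because nothing else separates the pair: the fact that compounds 3 and 4 differ only in the configuration as drawn

Going by these compounds, whether the preference for R holds with a longer chain at this carbon remains open. So does the weight of the other stereocentre.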